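Methoxy for dimethylamino on a benzofuran-bearing analogue

This account rests on a few compounds, and the source may have more. Where it says the series, first, only, none or still open, it means among the compounds named here.

Compound 2 `CN(C)c1ncnc2c1c(-c1ccoc1)cn2[C@@H]1O[C@H](CO)[C@@H](O)[C@H]1O` and compound 1 `COc1ncnc2c1c(-c1ccoc1)cn2[C@@H]1O[C@H](CO)[C@@H](O)[C@H]1O` share one core and differ in one group. In a functional assay on HeLa S3 cells (Homo sapiens) for antiproliferative activity, read by XTT assay, with a stated time of 72 h (a lower number here means a stronger inhibitor, a higher number a weaker inhibitor), compound 2 gives 9060 nM, while compound 1 gives 1790 nM. That change, (methoxy in place of dimethylamino on an aromatic carbon), made a 5.1-fold lower number from compound 2 to compound 1 (0.70 log units; beyond the scatter).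

Compound 3 `CN(C)c1ncnc2c1c(-c1cc3ccccc3o1)cn2[C@@H]1O[C@H](CO)[C@@H](O)[C@H]1O` differs from compound 2 by 1-benzofuran-2-yl in place of furan-3-yl on an aromatic carbon, which made an at least 2.2-fold higher number from compound 2 to compound 3 (0.34 log units; beyond the scatter). In this assay compound 3 reaches only a limit, > 20000 nM, which is one of the values that sit at the limit of > 20000 nM in this assay, at which 1 of the 3 values shown sits.

Compound 4 `COc1ncnc2c1c(-c1cc3ccccc3o1)cn2[C@@H]1O[C@H](CO)[C@@H](O)[C@H]1O` stands to compound 3 as compound 1 stands to compound 2: the change methoxy in place of dimethylamino on an aromatic carbon is the same one, at the same place. Because compound 1 showed a 5.1-fold lower number from compound 2 to compound 1 (0.70 log units; beyond the scatter), a step of similar size is expected here, an at least 2.2-fold lower number from compound 3 to compound 4 (0.34 log units; beyond the scatter), though the starting point of compound 3 is known only as a limit. The value estimated for compound 4 in this assay is 9000 nM, within 2500 nM to 40000 nM.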

Compound 4, half-maximal inhibitory concentration: 9240 nM
Estimate against measurement, compound 4: 1.0-fold (0.01 log units) below; low and high end bracket the measured number.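

Methoxy in place of dimethylamino lowers the number on both cores in this assay, and among the analogues carrying 1-benzofuran-2-yl the step is an at least 2.1-fold lower number from compound 3 to compound 4 (0.33 log units; beyond the scatter). Compound 3 stands only at a limit of the assay, > 20000 nM, so the direction of the change carries over but its size may or may not: the same change on two cores in this assay, a 5.1-fold lower number (0.70 log units; beyond the scatter) from compound 2 to compound 1 and an at least 2.1-fold lower number (0.33 log units; beyond the scatter) from compound 3 to compound 4; the limit leaves it open whether they differ Read the other way, 1-benzofuran-2-yl in place of furan-3-yl gives a 5.2-fold higher number from compound 1 to compound 4 (0.71 log units; beyond the scatter), the same direction as on the dimethylamino pair, and here too the size stays unsettled: the same change on two cores in this assay, an at least 2.2-fold higher number (0.34 log units; beyond the scatter) from compound 2 to compound 3 and a 5.2-fold higher number (0.71 log units; beyond the scatter) from compound 1 to compound 4; the limit leaves it open whether they differ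

Two cores are a small base for any rule. Going by these compounds, whether the same direction holds for other groups at this place, such as ethoxy or a primary amine, remains open.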